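The source may report more compounds than this note shows. Statements on the series, on what has been measured and on what is new or still open speak of the compounds shown alone.

Measured compounds in a functional assay on A-375 cells (Homo sapiens) for cytotoxicity, read by MTT assay, with a stated time of 72 h; on this read-out higher numbers stand for weaker inhibition and lower numbers for stronger inhibition:
- compound 1, `Cc1ccnc(/C(N)=N/NC(=S)N2CCSCC2)c1`: 1200 nM
- compound 2, `Cc1ccnc(/C(N)=N/NC(=S)N2CCCCCC2)c1`: 800 nM
- compound 3, `N/C(=N\NC(=S)N1CCCCCC1)c1ccccn1`: 740 nM

Compound 1 gives the highest of the three numbers in this assay, but its gap to compound 2 and its gap to compound 3 both lie within the usual scatter, so the three compounds cannot be told apart on these data. Among the measured compounds shown here, the only step between two measured compounds that differ in one place is a 1.1-fold lower number from compound 2 to compound 3 (0.03 log units; within the scatter), and it concerns a methyl group on an aromatic carbon, not the ring attached to the thiocarbonyl carbon.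

Compound 4, `Cc1ccnc(/C(N)=N/NC(=S)N2CCOCC2)c1`, differs from compound 1 as follows:

morpholin-4-yl in place of thiomorpholin-4-yl on a thiocarbonyl carbon

For the measured compounds named here, no measured pair shows what this exchange does in this assay, so there is no basis for expecting a shift in either direction beyond the scatter. Compound 4 is therefore expected to give about 1200 nM, in a range from 500 nM to 3000 nM, which is estimated as a step of no change at the digits printed from compound 1 to compound 4 (within the scatter).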

Compound 4, half-maximal inhibitory concentration: 1600 nM
Beside the measured number, compound 4's estimate is 1.3-fold (0.12 log units) below it, and the stated range covers the measured number.
By their numbers in this assay, from the lowest: compounds 3, 2, 1 and 4 (each within the scatter of the next, the first and the last beyond it).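

The exchange of thiomorpholin-4-yl for morpholin-4-yl on a thiocarbonyl carbon can now be read directly in this assay: it gives a 1.3-fold higher number from compound 1 to compound 4 (0.12 log units; within the scatter). At this position, then, replacing the ring sulfur with oxygen, with the ring size unchanged, produces no difference that can be told from the usual variation between repeated measurements. No other finding bears on this result, so it comes with no explanation.

This single pair leaves open whether the exchange would give the same result on a core without the methyl group shared by compound 1 and compound 4. It also leaves open whether a different group on the thiocarbonyl carbon, such as piperazin-1-yl or an open-chain diethylamino group, would shift the number beyond the scatter.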